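The source may report more compounds than this note shows. Statements on the series, on what has been measured and on what is new or still open speak of the compounds shown alone.

Three compounds built on one shared core were measured in an assay on CHO cells for displacement of a labelled ligand from 5-hydroxytryptamine receptor 1B (Homo sapiens); a higher number here means a weaker inhibitor, a lower number a stronger inhibitor. Compound 1 `c1ccc(CNCC2CCN(CCCc3c[nH]c4ccc(-n5cnnc5)cc34)CC2)cc1` gives 28 nM. Compound 2 `CN(Cc1cccs1)C1CCN(CCCc2c[nH]c3ccc(-n4cnnc4)cc23)CC1` gives 140 nM, and compound 3 `O[C@@H]1Cc2ccccc2[C@H]1NC1CCN(CCCc2c[nH]c3ccc(-n4cnnc4)cc23)CC1` gives 210 nM. Compound 3 therefore carries the highest number of the three: the step of a 7.5-fold higher number from compound 1 to compound 3 (0.88 log units; beyond the scatter) lies beyond the scatter, whereas the step of a 1.5-fold higher number from compound 2 to compound 3 (0.18 log units; within the scatter) lies within it, so compound 2 and compound 3 cannot be told apart on these numbers. Compound 4 `c1ccc2c(c1)CCC2NC1CCN(CCCc2c[nH]c3ccc(-n4cnnc4)cc23)CC1` has not yet been measured. It differs from compound 3 in one place: 2,3-dihydro-1H-inden-1-yl in place of 2-hydroxy-2,3-dihydro-1H-inden-1-yl on an amine nitrogen. For the measured compounds named here, no measured step removes a group in this way; the steps of a 5.0-fold higher number from compound 1 to compound 2 (0.70 log units; beyond the scatter) and a 7.5-fold higher number from compound 1 to compound 3 (0.88 log units; beyond the scatter) each exchange the whole group on the amine nitrogen, and both were modest. The measured steps thus give no direct guide, and the expectation rests on the small size of the change. The author expects a step of a 1.4-fold lower number from compound 3 to compound 4 (0.15 log units; within the scatter) that stays within the scatter. Compound 4 is estimated at 150 nM in this assay, with a range from 50 nM to 500 nM.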

Compound 4, half-maximal inhibitory concentration: 280 nM
Beside the measured number, compound 4's estimate is 1.9-fold (0.27 log units) below it; the range from low to high includes it.
By their numbers in this assay, from the lowest: compound 1; then compounds 2, 3 and 4 (each within the scatter of the next).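

In this assay the loss of the hydroxyl from the 2-hydroxy-2,3-dihydro-1H-inden-1-yl group on this amine nitrogen gives a 1.3-fold higher number from compound 3 to compound 4 (0.12 log units; within the scatter) and so cannot be told from no change, which means that the hydrogen-bond donor and acceptor counted in that group leave no readable mark on this number. The other two steps place the new group among the earlier ones: a 2.0-fold higher number from compound 2 to compound 4 (0.30 log units; within the scatter) leaves it indistinguishable from the methyl((thiophen-2-yl)methyl)amino group, while a 10-fold higher number from compound 1 to compound 4 (1.00 log units; beyond the scatter) shows that compound 1 with its (benzylamino)methyl group remains apart from compound 4 just as it does from compound 2 and compound 3. Nothing at hand accounts for these results.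

The compounds shown leave open whether an amine or a carboxylic acid in place of the hydroxyl would pass as quietly as its removal did. They also leave open whether a methyl group on this amine nitrogen or a one-carbon link to the 2,3-dihydro-1H-inden-1-yl group would bring the number in this assay closer to that of compound 1.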